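This account rests on a few compounds, and the source may have more. Where it says the series, first, only, none or still open, it means among the compounds named here.

In a functional assay on A549 cells (Homo sapiens) for inhibition, read by MTT assay, with a stated time of 48 h (a higher number here means a weaker inhibitor, a lower number a stronger inhibitor), compound 1 `Fc1ccc(/C=N/Nc2nc(-c3ccc(C(F)(F)F)cc3)cs2)cc1F` gives 2610 nM while compound 2 `COc1cc(/C=N/Nc2nc(-c3ccc(F)c(F)c3)cs2)c(Br)c(Br)c1OC` gives 8380 nM as its result. Compound 1 therefore holds the lower of the two numbers, which makes it the stronger inhibitor of this pair, and the gap between them lies beyond the usual scatter of repeat measurements. Compound 3 `Fc1ccc(/C=N/Nc2nc(-c3ccccc3)cs2)cc1F` keeps the core of compound 1 and alters one place, with hydrogen in place of trifluoromethyl on an aromatic carbon. For the measured compounds named here, no two measured compounds differ in just one place, so the data offer no direct guide to the size of this change. In this assay a modest rise in the number is expected, meaning a weaker inhibitor, little beyond the scatter, and the estimated step is a 2.3-fold higher number from compound 1 to compound 3 (0.36 log units; beyond the scatter) as a rough guess. Compound 3 is expected at about 6000 nM (estimated range 1800 nM to 20000 nM).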

Compound 3, half-maximal inhibitory concentration: 91400 nM
Compound 3: the middle estimate sits 15-fold (1.18 log units) below what was measured; measured number above the stated range.
By their numbers in this assay, from the lowest: compound 1; then compound 2; then compound 3.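

In this assay, for the compounds shown here, hydrogen in place of trifluoromethyl gives a 35-fold higher number from compound 1 to compound 3 (1.54 log units; beyond the scatter) and is the first step here that changes only one place. It shows that this position, on an aromatic carbon of a six-membered aromatic ring of carbon only and para to a large group, has a large effect on the measured inhibition. Nothing measured here explains why the loss is so large.

One step cannot tell whether the trifluoromethyl group is specifically needed or whether other groups at this position would also preserve inhibition. Going by these compounds, a methyl group, a chlorine atom or a nitrile at the same position would help separate these possibilities, and how much of the number each one restores remains open.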